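Methoxy for methyl on the anilino ring of compound 3

The compounds below may be only part of what the source reports. "The series", "measured", "known", "first", "only" and "open" are said of these compounds alone.

Measured compounds in a functional assay on MCF7 cells (Homo sapiens) for inhibition, read by MTT assay, with a stated time of 72 h; a lower number here means a stronger inhibitor, a higher number a weaker inhibitor:
- compound 1 `COc1ccc(Nc2nc(SCc3cn(Cc4ccccc4Cl)nn3)nc(-c3ccccc3)c2C#N)cc1` gives 8050 nM
- compound 2 `Cc1ccc(Nc2nc(SCc3cn(Cc4ccccc4Cl)nn3)nc(-c3ccccc3)c2C#N)cc1` gives 9420 nM
- compound 3 `Cc1ccc(Nc2nc(SCc3cn(Cc4ccccc4Cl)nn3)nc(-c3ccc(C(C)C)cc3)c2C#N)cc1` gives 12200 nM

Compound 3 has the highest of the three numbers, but its distance to compound 2 and to compound 1 is within the scatter, so the three compounds cannot be told apart on these data. Compound 4 `COc1ccc(Nc2nc(SCc3cn(Cc4ccccc4Cl)nn3)nc(-c3ccc(C(C)C)cc3)c2C#N)cc1` is not yet measured. It differs from compound 3 in one place: methoxy in place of methyl on an aromatic carbon, that is, (4-methylphenyl)amino becomes (4-methoxyphenyl)amino on the shared core. Within the data shown here, the one measured step that bears on this is the same change in the other direction, a 1.2-fold higher number from compound 1 to compound 2 (0.07 log units; within the scatter), made on the core carrying an unsubstituted phenyl rather than the 4-isopropylphenyl of compound 3. Among the measured compounds shown here, that step did not leave the scatter, and the only other step, a 1.3-fold higher number from compound 2 to compound 3 (0.11 log units; within the scatter), concerns a different position and is also within it. Compound 4 is therefore expected to sit close to compound 3, with an estimated step of a 1.2-fold lower number from compound 3 to compound 4 (0.07 log units; within the scatter). The estimate for compound 4 is 10500 nM, with a range from 5000 nM to 22000 nM.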

Compound 4, half-maximal inhibitory concentration: 10300 nM
The estimate for compound 4 lay 1.0-fold (0.01 log units) above the measured number; measured number inside the range.
By their numbers in this assay, from the lowest: compounds 1, 2, 4 and 3 (each within the scatter of the next).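

In this assay the step of a 1.2-fold lower number from compound 3 to compound 4 (0.07 log units; within the scatter) gives the exchange between 4-methylphenyl and 4-methoxyphenyl a reading on a second core, and the two readings agree: the same change on two cores in this assay, a 1.2-fold higher number (0.07 log units; within the scatter) from compound 1 to compound 2 and a 1.2-fold higher number (0.07 log units; within the scatter) from compound 4 to compound 3, 1.0-fold (0.01 log units) apart, within the scatter of two such steps. The change from hydrogen to isopropyl also gains a second reading, with a 1.3-fold higher number from compound 1 to compound 4 (0.11 log units; within the scatter) on the core carrying the methoxy group, and it agrees with the first: the same change on two cores in this assay, a 1.3-fold higher number (0.11 log units; within the scatter) from compound 2 to compound 3 and a 1.3-fold higher number (0.11 log units; within the scatter) from compound 1 to compound 4, 1.0-fold (0.01 log units) apart, within the scatter of two such steps. Neither change has given a step beyond the scatter on either core, so at this position methyl and methoxy cannot be told apart with either substituent pattern shown.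

The compounds shown hold only methyl and methoxy at this position, which leaves open whether any other group there can move the number beyond the scatter. A hydroxyl group, an amine, a carboxylic acid or a longer chain such as butoxy would put that question to the test.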